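The compounds below may be only part of what the source reports. "The series", "measured", "known", "first", "only" and "open" are said of these compounds alone.

Of the compounds shown here, three have been measured in a functional assay on L1210 cells (Mus musculus) for antiproliferative activity; a higher number here means a more potent compound, by a factor of ten per unit of this negative logarithm, a lower number a less potent compound. Compound 1 `CCCCN(C)/N=N/c1c(C(N)=O)n[nH]c1C` gives 3.83. Compound 2 `Cc1[nH]nc(C(N)=O)c1/N=N/N(C)C` gives 3.84. Compound 3 `COC(=O)c1[nH]cnc1/N=N/N(C)C` gives 3.86. All three numbers lie within the usual scatter of each other, so no order among them can be read from this assay.

Compound 1 and compound 2 share one core, and the step between them is propyl in place of hydrogen on a saturated chain carbon bound to an amine nitrogen. In this assay that step is a number 0.01 log units lower from compound 2 to compound 1 (within the scatter), a change that does not move the read-out.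

Compound 3 has a different core; the difference between the two cores is not broken down here. The unmeasured compound 4 `CCCCOC(=O)c1[nH]cnc1/N=N/N(C)C` is built from compound 3 by propyl in place of hydrogen on a saturated chain carbon bound to an oxygen next to a carbonyl group. The place is not the same as before: there the chain carbon was bound to an amine nitrogen, here it is bound to an oxygen next to a carbonyl group, so this is the same kind of change, not the same change.

Given that compound 2 to compound 1 gave a number 0.01 log units lower from compound 2 to compound 1 (within the scatter), the step from compound 3 to compound 4 is expected to be no change at the digits printed from compound 3 to compound 4 (within the scatter). Compound 4 is therefore estimated at 3.86, most likely between 3.5 and 4.25.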

Compound 4, logarithm of the reciprocal of the active concentration, log(1/C): 3.53
Compound 4: middle estimate off by 0.33 log units, on the high side, and the stated range covers the measured number.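

In this assay, the new step is a number 0.33 log units lower from compound 3 to compound 4 (beyond the scatter), with propyl in place of hydrogen on a saturated chain carbon bound to an oxygen next to a carbonyl group. Set beside the earlier step, this result gives no firm sign that the change behaves differently on the two cores: the same change on two cores in this assay, a number 0.01 log units lower (within the scatter) from compound 2 to compound 1 and a number 0.33 log units lower (beyond the scatter) from compound 3 to compound 4, 0.32 log units apart, within the scatter of two such steps This shows that the earlier step is compatible with the new one, but with only one pair on each core it does not show that the change carries over reliably, and the chain carbon is bound to an amine nitrogen in one pair and to an oxygen next to a carbonyl group in the other.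

The compounds shown leave open how a longer chain would read in this assay on either core, and whether a chain ending in an amine or a carboxylic acid would follow the same course. They also leave open whether the same change would give a similar step on a third core.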